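A few compounds are considered here, and "the series" means these few. Any claim that something is new, unique, unknown or untested is made for them only; others in the source may bear on it.

Compound 1 `COc1ccc(-c2cs/c(=N/NC(=O)CSc3ncccn3)n2-c2ccccc2)cc1` gives 89.6% in a functional assay on C6 cells (Rattus norvegicus) for cytotoxicity, read by MTT assay, with a stated time of 24 h, tested at 6 ug/mL; a lower number here means a stronger effect, a higher number a weaker effect of the compound at the concentration tested.
Compound 2 `COc1ccc(-c2cs/c(=N/NC(=O)CSc3nnc(C)s3)n2-c2ccccc2)cc1` gives 57.9% in this assay.

Compound 2 stands lowest of the two numbers. Among the measured compounds shown here, the only measured step is a number 31.7 percentage points lower from compound 1 to compound 2 (beyond the scatter), a change on a sulfur that leaves the 4-methoxyphenyl untouched. Compound 3 `Cc1nnc(SCC(=O)N/N=c2/scc(-c3ccc(Cl)cc3)n2-c2ccccc2)s1` differs from compound 2 in another place: chloro in place of methoxy on an aromatic carbon. For the measured compounds named here, no measured step bears on a change at this aromatic carbon, so the series gives no guide to the size of the step in this assay; with nothing pointing either way, no step beyond the scatter is expected. Compound 3 is therefore estimated at 58%, range 40% to 76%, the expected step being a number 0.1 percentage points higher from compound 2 to compound 3 (within the scatter).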

Compound 3, a percentage reported as activity, at one concentration (the size of the read-out at that concentration, not a potency): 82.8%
Compound 3: middle estimate off by 24.8 percentage points, on the low side, and the stated range ends below it.
By their numbers in this assay, from the lowest: compound 2; then compounds 3 and 1 (each within the scatter of the next).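

In this assay, the substituent on this aromatic carbon matters with 5-methyl-1,3,4-thiadiazol-2-yl held on the sulfur: with chloro in place of methoxy, the series shows a number 24.9 percentage points higher from compound 2 to compound 3 (beyond the scatter). The sulfur substituent is therefore not the only place in the series where a single change moves the read-out beyond the scatter. No available evidence accounts for this step.

Still open, as far as these compounds go, is whether the same change carries over with pyrimidin-2-yl on the sulfur. Also open, from the compounds shown here alone, is how an amine or a carboxylic acid on this aromatic carbon would read.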